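A few compounds are considered here, and "the series" means these few. Any claim that something is new, unique, unknown or untested is made for them only; others in the source may bear on it.

Compound 1 `COc1cc2ncnc(Nc3ccc(NC(=O)c4cccc(Cl)c4)cc3)c2cc1OC`: 12000 nM
Compound 2 `COc1cc2ncnc(Nc3ccc(NC(=O)c4ccc(Cl)cc4)cc3)c2cc1OC`: 28000 nM

In a functional assay on HepG2 cells (Homo sapiens) for inhibition, read by MTT assay (on this read-out higher numbers stand for weaker inhibition and lower numbers for stronger inhibition), compound 2 gives 28000 nM, the highest of the two numbers; its nearest neighbour, compound 1, gives 12000 nM. Compound 3 `COc1cc2ncnc(Nc3ccc(NC(=O)c4cc(F)ccc4Br)cc3)c2cc1OC` differs from compound 2 by 2-bromo-5-fluorophenyl in place of 4-chlorophenyl on a carbonyl carbon. For the measured compounds named here, the only measured step that concerns this ring, a 2.3-fold higher number from compound 1 to compound 2 (0.37 log units; beyond the scatter), shows that relocating a single chlorine already shifts the number modestly. Going by the values given here, no measured pair covers a ring carrying two halogens, nor one carrying bromine or fluorine, so the size of the present step cannot be read off directly. A step of about the same modest size, more likely toward a lower number than a higher one, is expected: a 1.6-fold lower number from compound 2 to compound 3 (0.19 log units; within the scatter). Compound 3 is therefore estimated at 18000 nM, within a range from 6000 nM to 50000 nM.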

Compound 3, half-maximal inhibitory concentration: 22000 nM
Beside the measured number, compound 3's estimate is 1.2-fold (0.09 log units) below it; the range from low to high includes it.
By their numbers in this assay, from the lowest: compounds 1, 3 and 2 (each within the scatter of the next, the first and the last beyond it).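

In this assay, 2-bromo-5-fluorophenyl in place of 4-chlorophenyl gives a 1.3-fold lower number from compound 2 to compound 3 (0.10 log units; within the scatter) and, in place of 3-chlorophenyl, gives a 1.8-fold higher number from compound 1 to compound 3 (0.26 log units; within the scatter) on the same carbonyl carbon. This position therefore accepts a ring with two halogens, bromine and fluorine, and 8 heavy atoms rather than 7, with neither step beyond the scatter, whereas the earlier pair showed only a single chlorine changing place. No supporting measurement bears on why the number holds with this ring.

The compounds shown leave open whether the bromine or the fluorine alone would give the same number. They also leave open whether a ring carrying an amine or a carboxylic acid, or a longer chain in place of the ring, would give a number clearly apart from these.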